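A few compounds are considered here, and "the series" means these few. Any claim that something is new, unique, unknown or untested is made for them only; others in the source may bear on it.

Measured compounds:
- compound 1, `O=C(NCc1ccc(CNS(=O)(=O)c2ccccc2)cc1)c1cccc(F)c1`: 100 nM
- compound 2, `Cc1ccc(S(=O)(=O)NCc2ccc(CNC(=O)c3ccccc3Cl)cc2)cc1`: 10 nM
- compound 3, `Cc1ccc(S(=O)(=O)NCc2ccc(CNC(=O)c3cccc(F)c3)cc2)cc1`: 1 nM

In an assay on MDA-MB-231 cells for binding affinity to C-X-C chemokine receptor type 4 (Homo sapiens), read by immunofluorescence and microscopy, with stated times of 10 min and 30 min (a lower number here means that less compound is needed, a higher number that more compound is needed for the effect), compound 1 gives the highest of the three numbers, so of the three it needs the most compound. Its nearest neighbour is compound 2, and the step of a 100-fold lower number from compound 1 to compound 3 (2.00 log units; beyond the scatter) is the largest gap in the set, coming from a methyl in place of hydrogen on an aromatic carbon.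

Compound 4, `O=C(NCc1ccc(CNS(=O)(=O)c2ccccc2)cc1)c1ccc(Cl)cc1`, has not been measured in this assay. It differs from compound 1 in one place: 4-chlorophenyl in place of 3-fluorophenyl on a carbonyl carbon. Among the compounds with values here, the one measured step that bears on this part of the shared core is a 10-fold lower number from compound 2 to compound 3 (1.00 log units; beyond the scatter), where a different aromatic ring on the carbonyl carbon moved the number by a modest amount. That step shows the ring on the carbonyl carbon matters, but it does not involve a 4-chlorophenyl, so its direction cannot be carried over. Within the data shown here, no other step touches this position.

The change in compound 4 is therefore expected to keep the number near that of compound 1, with a step of a 1.5-fold higher number from compound 1 to compound 4 (0.18 log units; within the scatter) that is expected to stay within the scatter. For compound 4 the estimate in this assay is 150 nM, with a range from 30 nM to 800 nM.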

Compound 4, effective concentration (reported as EC, without a stated level of effect): 100 nM
Estimate against measurement, compound 4: 1.5-fold (0.18 log units) above; the measured number falls inside the stated range.
By their numbers in this assay, from the lowest: compound 3; then compound 2; then compounds 1 and 4 (each within the scatter of the next).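

In this assay the swap to 4-chlorophenyl on a carbonyl carbon gives no change at the digits printed from compound 1 to compound 4 (within the scatter) and so leaves the number where it was, which shows that a new ring at this position does not always shift the result. The earlier step, a 10-fold lower number from compound 2 to compound 3 (1.00 log units; beyond the scatter), showed only that this position can matter; read beside it, the new step shows that the effect depends on the particular pair of rings or on the rest of the molecule, since the two steps were taken on compounds with different sulfonyl groups. Nothing available explains why this swap is silent while the earlier one is not.

The compounds shown leave open whether 4-chlorophenyl would also match 3-fluorophenyl in the presence of the methyl that separates compound 1 from compound 3, where the number is much lower. They also leave open how this position would respond to a group of another kind on the carbonyl carbon, such as a phenyl ring carrying an amine or a carboxylic acid, or a longer carbon chain in place of the ring.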